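The compounds below may be only part of what the source reports. "The series", "measured", "known", "first", "only" and "open" are said of these compounds alone.

Measured compounds in a functional assay on U-87MG ATCC cells for antiproliferative activity against U-87 MG (Homo sapiens), read by MTT assay, with a stated time of 72 h; a higher number here means a weaker inhibitor, a lower number a stronger inhibitor:
compound 1 `O=C(Nc1ccc(Oc2ccnc3[nH]ccc23)cc1)c1cc2cccnc2n(-c2ccccc2)c1=O`: 1580 nM
compound 2 `O=C(Nc1ccc(Oc2ccnc3[nH]ccc23)cc1)c1cc2cccnc2n(-c2ccc(F)c(Cl)c2)c1=O`: "not determined" (no result reported)
compound 3 `Cn1ccc2c(Oc3ccc(NC(=O)c4cc5cccnc5n(-c5ccccc5)c4=O)cc3)ccnc21`: 5030 nM

In this assay compound 3 stands highest of the two numbers. Its nearest neighbour is compound 1, and the gap, a 3.2-fold higher number from compound 1 to compound 3 (0.50 log units; beyond the scatter), came from methyl in place of hydrogen on an aromatic nitrogen. Compound 2 contributes no number to the comparison.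

Compound 4 `COc1ccc(-n2c(=O)c(C(=O)Nc3ccc(Oc4ccnc5c4ccn5C)cc3)cc3cccnc32)cc1` differs from compound 3 by methoxy in place of hydrogen on an aromatic carbon, in words methoxy in place of hydrogen on an aromatic carbon. For the measured compounds named here, no measured step bears on this change: the one step available concerns a different part of the shared core, so nothing in the data says how the ring of carbon only responds to a methoxy group. In the absence of any guide, the expected step of a 1.1-fold lower number from compound 3 to compound 4 (0.05 log units; within the scatter) is none beyond the scatter, with a wide range to reflect the lack of precedent. Compound 4 is therefore estimated at 4500 nM in this assay, between 1400 nM and 14000 nM.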

Compound 4, half-maximal inhibitory concentration: 5150 nM
The estimate for compound 4 lay 1.1-fold (0.06 log units) below the measured number; the measured number falls inside the stated range.
By their numbers in this assay, from the lowest: compound 1; then compounds 3 and 4 (each within the scatter of the next).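

In this assay the change from phenyl to 4-methoxyphenyl amounts to a 1.0-fold higher number from compound 3 to compound 4 (0.01 log units; within the scatter) and so leaves the number unmoved within the scatter. For the compounds shown here, this is the first reading on the six-membered aromatic ring of carbon only, as the earlier step, a 3.2-fold higher number from compound 1 to compound 3 (0.50 log units; beyond the scatter) and beyond the scatter, concerned an aromatic nitrogen of the shared core. No measurement shown here offers an explanation for this result.

The compounds shown leave open whether a different group at this same place, such as an amine, a carboxylic acid or a longer alkoxy chain, would shift the number. They also leave open whether methoxy would behave the same way with the hydrogen kept on the aromatic nitrogen, as in compound 1.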